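The source may report more compounds than this note shows. Statements on the series, on what has been measured and on what is new or still open speak of the compounds shown alone.

Measured compounds in an assay on isolated protein for inhibition of histone acetyltransferase KAT2B (Homo sapiens), read by fluorescence, with a stated time of 10 min, tested at 50 uM; a higher number here means more inhibition at the concentration tested (going by the name of the read-out), a lower number less inhibition:
compound 1, `O=c1c2cc([N+](=O)[O-])cnc2sn1-c1ccc(Oc2ccccc2)cc1`, gives 94%;
compound 2, `CCOC(=O)Cn1sc2nc(C)cc(C)c2c1=O`, gives 97%;
compound 3, `CC(C)CNC(=O)Cn1sc2ccccc2c1=O`, gives 95%.

The three measured compounds share the same core and all give a high number at the single concentration tested. Compound 3 stands between the other two on the numbers, but its gap to compound 1 and its gap to compound 2 both lie within the usual scatter of this assay, so the three values cannot be told apart with any confidence; none of them can be said to have a higher or lower number than the others.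

Compound 4, `O=C(Cn1sc2ccccc2c1=O)Nc1nccs1`, has not yet been measured. It differs from compound 3 in one place: 1,3-thiazol-2-yl in place of isobutyl on an amide-type nitrogen. For the measured compounds named here, since no pair of measured compounds differs in a single place, there is no measured step to lean on. What the data do show is that three rather different substituents on this core all give a number near the top of the scale, which leaves little room for an upward step and gives no reason to predict a large downward one. Compound 4 is therefore expected to show a step of a number 3 percentage points lower from compound 3 to compound 4 (within the scatter), within the scatter. The inhibition of compound 4 in this assay is estimated at 92%, with a range of 72% to 99%.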

Compound 4, a percentage reported as inhibition, at one concentration (the size of the read-out at that concentration, not a potency): 97%
Compound 4: the middle estimate sits 5 percentage points below what was measured; measured number inside the range.
By their numbers in this assay, from the lowest: compounds 1, 3, 2 and 4 (each within the scatter of the next).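

In this assay, 1,3-thiazol-2-yl in place of isobutyl on an amide-type nitrogen gives a number 2 percentage points higher from compound 3 to compound 4 (within the scatter), the first single-place step available in this series. It shows that this nitrogen can carry a five-membered aromatic ring with 2 hetero atoms instead of an open branched chain without any readable difference in the number, even though the entering group brings 2 hydrogen-bond acceptors and the leaving group brings none. Nothing measured here accounts for this result, and the values alone offer no explanation of it.

All of these numbers sit near the top of the scale at one concentration, so this step cannot show whether the two groups would still match at a lower concentration, where any difference between them would have more room to appear. From the compounds shown here alone, it also remains open whether a methyl group, a carboxylic acid or a longer chain on the same amide-type nitrogen would give a number as high as those of the isobutyl and 1,3-thiazol-2-yl groups.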